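The source may report more compounds than this note shows. Statements on the series, on what has been measured and on what is new or still open speak of the compounds shown alone.

Measured in a functional assay on HepG2 cells (Homo sapiens), read by MTT assay, with a stated time of 48 h; a higher number here means a weaker inhibitor, a lower number a stronger inhibitor:
- Compound 1 `CCN(CC)CCCNC(=O)c1ccc(C(CC)(CC)c2ccc(OCC(O)C(C)(C)C)c(C)c2)n1CC`: 1100 nM
- Compound 2 `CCn1c(C(=O)N(C)CCC#N)ccc1C(CC)(CC)c1ccc(OCC(O)C(C)(C)C)c(C)c1`: > 50000 nM, a limit of the assay
- Compound 3 `C=CCN(C)C(=O)c1ccc(C(CC)(CC)c2ccc(OCC(O)C(C)(C)C)c(C)c2)n1CC`: > 50000 nM, a limit of the assay

Compound 3 has no exact number in this assay, only a limit. Compound 2 is in the same position, as the limit of > 50000 nM in this assay, at which 2 of the 3 values shown sit, shows.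

Compound 4 `CC[C@@H](C)[C@H](NC(=O)c1ccc(C(CC)(CC)c2ccc(OCC(O)C(C)(C)C)c(C)c2)n1CC)C(=O)O` carries (1-carboxy-2-methylbutyl)amino in place of the allyl(methyl)amino of compound 3, on a carbonyl carbon: (1-carboxy-2-methylbutyl)amino in place of allyl(methyl)amino on a carbonyl carbon.

Two measured steps change this same place: an at least 45-fold higher number from compound 1 to compound 2 (1.65 log units; beyond the scatter), and an at least 45-fold higher number from compound 1 to compound 3 (1.65 log units; beyond the scatter). Both are large, and both remove the (3-(diethylamino)propyl)amino group. Compound 4 lacks that group too, so it resembles compound 2 and compound 3 in this respect, and only compound 1 gave an exact number. The step between compound 2 and compound 3 cannot be read, so it adds nothing here.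

No step beyond the scatter is expected in this assay, and the estimated step is a number no higher from compound 3 to compound 4 (the limit leaves the size open). For compound 4, the expected value is 50000 nM, with an estimated range of 15000 nM to 100000 nM.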

Compound 4, half-maximal inhibitory concentration: 127 nM
Beside the measured number, compound 4's estimate is 390-fold (2.60 log units) above it, and the stated range ends above it.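

Until now, only the (3-(diethylamino)propyl)amino group on this carbonyl carbon had given an exact number, but compound 4 shows that a group without that diethylamino end can also do so in this assay: there is an at least 390-fold lower number from compound 3 to compound 4 (2.59 log units; beyond the scatter), and an at least 390-fold lower number from compound 2 to compound 4 (2.59 log units; beyond the scatter). The (1-carboxy-2-methylbutyl)amino group also outperforms the diethylamino chain, with an 8.7-fold lower number from compound 1 to compound 4 (0.94 log units; beyond the scatter). The steps from compound 2 and compound 3 start from a limit, so their full size stays open: the limit of > 50000 nM in this assay, at which 2 of the 4 values shown sit.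

Compound 4 brings a carboxylic acid, a branched chain and two defined stereocentres together, and the compounds shown do not separate their contributions. Going by these compounds, whether a methyl ester in place of the carboxylic acid, or a simple butyl chain without it, would keep this strength remains open.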